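Removing the pyrazole methyl from the weakest sulfonylguanidine

The compounds below may be only part of what the source reports. "The series", "measured", "known", "first", "only" and "open" are said of these compounds alone.

Measured compounds in a functional assay on HeLa cells (Homo sapiens) for cytotoxicity, read by MTT assay, with a stated time of 72 h; a lower number here means a stronger inhibitor, a higher number a weaker inhibitor:
Compound 1, `Cc1cc(-c2ccccc2)n(/C(N)=N/S(=O)(=O)c2cc(C)c(Cl)cc2SCc2cccc3ccccc23)n1`, gives 3000 nM.
Compound 2, `Cc1cc(-c2ccccc2)n(/C(N)=N/S(=O)(=O)c2cc(C)c(Cl)cc2SCc2cccc(C(F)(F)F)c2)n1`, gives 98000 nM.
Compound 3, `Cc1cc(-c2ccccc2)n(/C(N)=N/S(=O)(=O)c2cc(C)c(Cl)cc2SCc2cccc(Cl)c2)n1`, gives 8000 nM.

Compound 2 stands at the top of these three numbers, the weakest of the set: its nearest neighbour is compound 3, reached by a 12-fold lower number from compound 2 to compound 3 (1.09 log units; beyond the scatter), and the furthest is compound 1, from which it is separated by a 33-fold higher number from compound 1 to compound 2 (1.51 log units; beyond the scatter). Both of those steps are well beyond the scatter, and so is a 2.7-fold higher number from compound 1 to compound 3 (0.43 log units; beyond the scatter).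

Compound 4, `Cc1cc(S(=O)(=O)/N=C(\N)n2nccc2-c2ccccc2)c(SCc2cccc(C(F)(F)F)c2)cc1Cl`, has not yet been measured. It differs from compound 2 in one place: hydrogen in place of methyl on an aromatic carbon. All three measured steps concern the group on the saturated chain carbon bound to sulfur, on the far side of the shared core from this ring. Among the measured compounds shown here, none of them touches the five-membered aromatic ring with two nitrogens, so no measured step bears on the change from compound 2 to compound 4. With nothing in the data pointing either way, a step within the scatter is expected, which is what a 1.0-fold higher number from compound 2 to compound 4 (0.01 log units; within the scatter) means. Compound 4 is therefore estimated at 100000 nM, with a range from 35000 nM to 300000 nM.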

Compound 4, half-maximal inhibitory concentration: 19000 nM
For compound 4 the middle estimate is 5.3-fold (0.72 log units) above the measured one; measured number outside the range, below it.
By their numbers in this assay, from the lowest: compound 1; then compound 3; then compound 4; then compound 2.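

In this assay, the change from 3-methyl-5-phenyl-1H-pyrazol-1-yl to 5-phenyl-1H-pyrazol-1-yl gives a 5.2-fold lower number from compound 2 to compound 4 (0.71 log units; beyond the scatter), a modest step but one beyond the scatter. Among the compounds shown here, every earlier step concerned the group on the saturated chain carbon bound to sulfur, so this is the first sign that the number also responds to a change elsewhere: on an aromatic carbon of the five-membered ring, two ring bonds from the ring atom that bears the phenyl group, where the loss of a single carbon makes compound 4 the stronger of this pair. Nothing available here accounts for the size or direction of this step.

The compounds shown leave open whether removing the methyl would lower the number to a similar extent with the naphthalen-1-yl group of compound 1 or the 3-chlorophenyl group of compound 3, as the change can be read only with the 3-(trifluoromethyl)phenyl group. They also leave open how an ethyl group, an amine or a carboxylic acid on the same aromatic carbon would compare with hydrogen and methyl.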